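The compounds below may be only part of what the source reports. "The series", "measured", "known", "first", "only" and "open" are said of these compounds alone.

Measured so far in a functional assay (Cavia porcellus) for inhibition of cysteinyl leukotriene receptor (Homo sapiens); a lower number here means a stronger inhibitor, a higher number a weaker inhibitor:
- compound 1 `c1cc(OCc2ccc3ccccc3n2)cc(OCc2nn[nH]n2)c1`: 140 nM
- compound 2 `c1ccc2nc(COc3ccc(CCc4nnn[nH]4)cc3)ccc2c1`: 280 nM
- compound 3 `c1ccc2nc(COc3ccc(OCCCc4nnn[nH]4)cc3)ccc2c1`: 250 nM

Compound 1 gives the smallest of the three numbers, but its distances to compound 3 and to compound 2 both lie within the scatter, so the three measured compounds cannot be told apart on this assay. Among the compounds with values here, the one step between measured compounds that differ in a single place, a 1.1-fold lower number from compound 2 to compound 3 (0.05 log units; within the scatter), changes only the linker between the shared core and the tetrazole and leaves the tetrazole in place; it was within the scatter.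

The unmeasured compound 4 `CCOC(=O)CCCOc1cccc(OCc2ccc3ccccc3n2)c1` differs from compound 1 in a different way: 2-(ethoxycarbonyl)ethyl in place of 2H-tetrazol-5-yl on a saturated chain carbon bound to an oxygen on an aromatic ring. Within the data shown here, every measured compound carries the tetrazole, and no measured step removes it, so the step from compound 2 to compound 3 does not bear on this change; nothing here calibrates it. The expectation therefore rests on the structural change alone and is wide. Compound 4 is expected to give a higher number than compound 1, estimated as a 21-fold higher number from compound 1 to compound 4 (1.33 log units; beyond the scatter). The estimate for compound 4 in this assay is 3000 nM, with a range from 500 nM to 20000 nM, and a real chance that only a limit is reported.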

Compound 4, half-maximal inhibitory concentration: 600 nM
For compound 4 the middle estimate is 5.0-fold (0.70 log units) above the measured one; the range from low to high includes it.
By their numbers in this assay, from the lowest: compounds 1, 3 and 2 (each within the scatter of the next); then compound 4.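

In this assay, the tetrazole is not required for a measurable number at this position: compound 4, which has no ring in the entering group, gives 600 nM. Within the data shown here, the replacement still has a cost, with a 4.3-fold higher number from compound 1 to compound 4 (0.63 log units; beyond the scatter), and this is the first step that leaves the scatter and the first that removes the tetrazole rather than changing the linker that carries it. No supporting measurement bears on the size of this step.

The change from (2H-tetrazol-5-yl)methoxy to 3-(ethoxycarbonyl)propoxy alters both the chain and its end group, so the compounds shown do not separate the contribution of the longer chain from that of the exchange of tetrazole for ester. Going by these compounds, a carboxylic acid at the end of the same propoxy chain, or a tetrazole carried on that chain on the core of compound 1, would address these two parts, and whether other replacements at this position match compound 1 remains open.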